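Chloropyridinyl amide in place of cyclohexyl on the core

A few compounds are considered here, and "the series" means these few. Any claim that something is new, unique, unknown or untested is made for them only; others in the source may bear on it.

Among the compounds with values here, in a functional assay on HeLa cells (Homo sapiens) for inhibition, read by MTT assay, with a stated time of 72 h (on this read-out lower numbers stand for stronger inhibition and higher numbers for weaker inhibition), compound 2 `Cc1noc(C)c1-c1cnc(N)c(Oc2ccc(C(=O)NC3CCCCC3)cc2)n1` gives 26100 nM, the highest of the three numbers so far. Compound 1 `Cc1noc(C)c1-c1cnc(N)c(Oc2ccc(C(=O)NC3CCCC3)cc2)n1` gives 9970 nM, and compound 3 `Cc1noc(C)c1-c1cnc(N)c(Oc2ccc(C(=O)Nc3cccc(Cl)n3)cc2)n1` gives 25500 nM. The step from compound 1 to compound 2 was a 2.6-fold higher number from compound 1 to compound 2 (0.42 log units; beyond the scatter), that from compound 1 to compound 3 was a 2.6-fold higher number from compound 1 to compound 3 (0.41 log units; beyond the scatter), whereas a 1.0-fold lower number from compound 2 to compound 3 (0.01 log units; within the scatter). Compound 4 `Cc1noc(C)c1-c1cnc(N)c(Oc2ccc(C(=O)Nc3ccc(Cl)cn3)cc2)n1` differs from compound 2 by 5-chloropyridin-2-yl in place of cyclohexyl on an amide-type nitrogen. Within the data shown here, the closest precedent is the exchange of cyclohexyl for 6-chloropyridin-2-yl, where a 1.0-fold lower number from compound 2 to compound 3 (0.01 log units; within the scatter). On that precedent the step to compound 4 is expected to stay within the scatter in this assay, a 1.0-fold lower number from compound 2 to compound 4 (0.02 log units; within the scatter). Compound 4 is therefore estimated at 25000 nM, with a range from 10000 nM to 60000 nM.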

Compound 4, half-maximal inhibitory concentration: 19200 nM
Beside the measured number, compound 4's estimate is 1.3-fold (0.11 log units) above it, within the range that was stated.
By their numbers in this assay, from the lowest: compounds 1, 4, 3 and 2 (each within the scatter of the next, the first and the last beyond it).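

In this assay the second chloropyridinyl amide again stays level with the cyclohexyl amide (a 1.4-fold lower number from compound 2 to compound 4 (0.13 log units; within the scatter)), and exchanging 6-chloropyridin-2-yl for 5-chloropyridin-2-yl on the amide-type nitrogen also stays within the scatter (a 1.3-fold lower number from compound 3 to compound 4 (0.12 log units; within the scatter)). The cyclopentyl amide, which stood apart from both the cyclohexyl and the 6-chloropyridin-2-yl amides, does not stand clearly apart from this one (a 1.9-fold higher number from compound 1 to compound 4 (0.28 log units; within the scatter)). Nothing available explains these small steps. Still open, as far as these compounds go, is whether the chlorine matters at all, and how an unsubstituted pyridin-2-yl, a phenyl or a cyclobutyl on the amide-type nitrogen would compare.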